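Compound 3 gives way to a (pyrrolidin-1-yl)carbonyl group

This account rests on a few compounds, and the source may have more. Where it says the series, first, only, none or still open, it means among the compounds named here.

In a functional assay on A549 cells (Homo sapiens) for antiproliferative activity, read by MTT assay, with a stated time of 48 h (a higher number here means a weaker inhibitor, a lower number a stronger inhibitor), compound 3 `COCOC/C1=C/C[C@](C)(CCC=C(C)C)/C=C/[C@@H](OC(=O)C=C(C)C)[C@](C)(O)/C=C/C1=O` gives 2980 nM. Compound 1 `CC(=O)OC/C1=C/C[C@](C)(CCC=C(C)C)/C=C/[C@@H](OC(=O)C=C(C)C)[C@](C)(O)/C=C/C1=O` gives 2950 nM, and a 1.0-fold higher number from compound 1 to compound 3 (0.00 log units; within the scatter) places the two within the scatter of each other. Compound 2 `CC(C)=CCC[C@]1(C)/C=C/[C@@H](OC(=O)C=C(C)C)[C@](C)(O)/C=C/C(=O)/C(CCl)=C\C1` gives 150 nM, and a 20-fold higher number from compound 2 to compound 3 (1.30 log units; beyond the scatter) shows how far compound 3 stands from it. Compound 4 `CC(C)=CCC[C@]1(C)/C=C/[C@@H](OC(=O)C=C(C)C)[C@](C)(O)/C=C/C(=O)/C(C(=O)N2CCCC2)=C\C1` has (pyrrolidin-1-yl)carbonyl in place of (methoxymethoxy)methyl on a double-bonded ring carbon. The measured steps that bear on this change are those made at the same ring carbon's substituent. Exchanging one oxygen-linked group for another there gave no change beyond the scatter, as a 1.0-fold higher number from compound 1 to compound 3 (0.00 log units; within the scatter) shows, whereas the one large drop, a 20-fold lower number from compound 1 to compound 2 (1.29 log units; beyond the scatter), came with chloro, which compound 4 does not carry. No amide has been measured, so this reasoning is only a loose guide. No step beyond the scatter is therefore expected, and the expected change is a 1.2-fold lower number from compound 3 to compound 4 (0.08 log units; within the scatter). In this assay, the estimate for compound 4 is 2500 nM, with an expected range of 700 nM to 9000 nM.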

Compound 4, half-maximal inhibitory concentration: 13000 nM
Compound 4: middle estimate off by 5.2-fold (0.72 log units), on the low side, and the stated range ends below it.
By their numbers in this assay, from the lowest: compound 2; then compounds 1 and 3 (each within the scatter of the next); then compound 4.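

In this assay, among these compounds, the (pyrrolidin-1-yl)carbonyl group is the only one at this double-bonded ring carbon that raises the number beyond the scatter against the oxygen-linked groups, with a 4.4-fold higher number from compound 3 to compound 4 (0.64 log units; beyond the scatter) and a 4.4-fold higher number from compound 1 to compound 4 (0.64 log units; beyond the scatter) as modest steps, while an 87-fold higher number from compound 2 to compound 4 (1.94 log units; beyond the scatter) is a large one. The earlier compounds had shown this position only as unchanged between the two oxygen-linked groups or as lowered by chloromethyl, so it now moves in both directions, with compound 2 and compound 4 at the two ends of the four numbers. No supporting data are available to account for this rise.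

As far as these compounds go, whether the rise belongs to the carbonyl or to the pyrrolidine ring stays open, and a primary amide, a piperidine amide or a carboxylic acid at this carbon would help separate the two. It is also unknown whether bromomethyl or hydroxymethyl would stand with chloromethyl or with the oxygen-linked groups.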